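The source may report more compounds than this note shows. Statements on the series, on what has been measured and on what is new or still open speak of the compounds shown alone.

Compound 1 `CCN(CC)CCCNC(=O)c1ccc(C(CC)(CC)c2ccc(OCC(=O)C(C)(C)C)c(C)c2)n1CC` gives 22 nM in an assay on HL-60 cells for agonist activity at vitamin D3 receptor (Homo sapiens), read by microscopy, with a stated time of 96 h; a lower number here means that less compound is needed, a higher number that more compound is needed for the effect. Compound 2 `CCn1c(C(=O)OC(C)CCO)ccc1C(CC)(CC)c1ccc(OCC(=O)C(C)(C)C)c(C)c1` gives 380 nM in this assay, so a 17-fold higher number from compound 1 to compound 2 (1.24 log units; beyond the scatter). Compound 3 `CCn1c(C(=O)Nc2ccc(OC(F)(F)F)cc2)ccc1C(CC)(CC)c1ccc(OCC(=O)C(C)(C)C)c(C)c1` reaches only the limit of this assay, > 50000 nM, and the limit of > 50000 nM in this assay, at which 1 of the 3 values shown sits, is all that is known of its standing. The two steps into it were large: an at least 2200-fold higher number from compound 1 to compound 3 (3.35 log units; beyond the scatter) and an at least 130-fold higher number from compound 2 to compound 3 (2.11 log units; beyond the scatter). Compound 4 `CCn1c(C(=O)Nc2cccc(C(F)(F)F)c2)ccc1C(CC)(CC)c1ccc(OCC(=O)C(C)(C)C)c(C)c1` differs from compound 3 by 3-(trifluoromethyl)phenyl in place of 4-(trifluoromethoxy)phenyl on an amide-type nitrogen, a change at the same amide-type nitrogen. Within the data shown here, no measured step separates two such arylamides, so no movement beyond the scatter is expected, and the result will most likely again be a limit. Compound 4 is therefore estimated at 50000 nM, between 10000 nM and 200000 nM. The expected step is a number no higher from compound 3 to compound 4 (the limit leaves the size open).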

Compound 4, half-maximal effective concentration: > 50000 nM
Compound 4 ended at the assay's limit; the forecaster's own chance of this, stated with the estimate: 70%; the middle value sits exactly at the limit.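

With 3-(trifluoromethyl)phenyl on the amide-type nitrogen, the large loss seen with compound 3 recurs with a second aryl group, so it is not confined to 4-(trifluoromethoxy)phenyl: an at least 2200-fold higher number from compound 1 to compound 4 (3.35 log units; beyond the scatter) and an at least 130-fold higher number from compound 2 to compound 4 (2.11 log units; beyond the scatter). Both arylamides now stand at a limit of this assay, so the step between compound 3 and compound 4 cannot be read: the limit of > 50000 nM in this assay, at which 2 of the 4 values shown sit. Still open, as far as these compounds go, is whether a phenyl ring carrying an amine would come back under the limit, and whether a shorter chain such as 2-(diethylamino)ethyl on this nitrogen would keep the number of compound 1.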